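Swapping a butoxy carbamate tail for an aminopropyl carbamate

The source may report more compounds than this note shows. Statements on the series, on what has been measured and on what is new or still open speak of the compounds shown alone.

Compound 1 `Cc1cn(C2CC(N=[N+]=[N-])C(COC(=O)NCCCO)O2)c(=O)[nH]c1=O` in a functional assay on MT4 cells (Homo sapiens) for cytotoxicity (on this read-out higher numbers stand for lower toxicity in this test and lower numbers for higher toxicity in this test), gives > 50000 nM, a limit of the test. Compound 2 `Cc1cn(C2CC(N=[N+]=[N-])C(COC(=O)NCCCC(=O)OC(C)(C)C)O2)c(=O)[nH]c1=O` gives > 50000 nM, again a limit. Compound 3 `CCCCOC(=O)OCC1OC(n2cc(C)c(=O)[nH]c2=O)CC1N=[N+]=[N-]` gives > 50000 nM, also a limit.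

Compound 3 therefore stands only at a limit, and so do both of its neighbours, since (the limit of > 50000 nM in this assay, at which 3 of the 3 values shown sit). The two measured steps give no readable size: a step that the two limits leave unreadable from compound 1 to compound 2 and a step that the two limits leave unreadable from compound 1 to compound 3 are each bounded on both sides by the same limit. Compound 4 `Cc1cn(C2CC(N=[N+]=[N-])C(COC(=O)NCCCN)O2)c(=O)[nH]c1=O` differs from compound 3 by (3-aminopropyl)amino in place of butoxy on a carbonyl carbon. The step from compound 1 to compound 3 exchanges a similar carbamate-for-carbonate pair, with both partners at the limit, so no direction and no size can be drawn from it. Compound 4 is accordingly expected to sit at the limit as well, and the estimate for compound 4 is 80000 nM, between 30000 nM and 300000 nM. The expected step is therefore a step that the limit leaves unreadable from compound 3 to compound 4, none beyond the scatter.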

Compound 4, half-maximal cytotoxic concentration: > 50000 nM
Compound 4: no number, only a limit; the forecaster's own chance of this, stated with the estimate: 85%; the middle value is on the limit's open side.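

Compound 4 sits at a limit in this assay, as do compound 1, compound 2 and compound 3, so none of the steps among them can be read: the limit of > 50000 nM in this assay, at which 4 of the 4 values shown sit.

The compounds shown leave open whether these four differ from one another at all in this assay.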